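Adding a Second Bromo to Compound 3

The source may report more compounds than this note shows. Statements on the series, on what has been measured and on what is new or still open speak of the compounds shown alone.

In a functional assay on HepG2 cells (Homo sapiens) for antiproliferative activity, read by MTT assay, with a stated time of 72 h (a lower number here means a stronger inhibitor, a higher number a weaker inhibitor), compound 1 (`O=C(N/N=C/c1ccc(F)cc1)Nc1ccc(Oc2ccnc3[nH]ccc23)c(F)c1`) reads 3880 nM and compound 2 (`O=C(N/N=C/c1cccc([N+](=O)[O-])c1)Nc1ccc(Oc2ccnc3[nH]ccc23)c(F)c1`) reads 5180 nM, while compound 3 (`O=C(N/N=C/c1ccc(O)c(Br)c1)Nc1ccc(Oc2ccnc3[nH]ccc23)c(F)c1`) stands at 1360 nM as the lowest of the three numbers. Still unmeasured is compound 4 (`O=C(N/N=C/c1cc(Br)c(O)c(Br)c1)Nc1ccc(Oc2ccnc3[nH]ccc23)c(F)c1`), which differs from compound 3 in one place (bromo in place of hydrogen on an aromatic carbon): bromo in place of hydrogen on an aromatic carbon, so 3-bromo-4-hydroxyphenyl becomes 3,5-dibromo-4-hydroxyphenyl. Going by the values given here, no measured step adds a bromo alone. The nearest evidence is the entry of 3-bromo-4-hydroxyphenyl, which gave a 2.9-fold lower number from compound 1 to compound 3 (0.46 log units; beyond the scatter) and a 3.8-fold lower number from compound 2 to compound 3 (0.58 log units; beyond the scatter) as modest steps, while the swap to 3-nitrophenyl showed only a 1.3-fold higher number from compound 1 to compound 2 (0.13 log units; within the scatter) here. A small further fall in this assay is therefore expected, and the estimated move is a 1.4-fold lower number from compound 3 to compound 4 (0.13 log units; within the scatter) and may not exceed the scatter. For compound 4 the expected value is 1000 nM within a range of 400 nM to 2600 nM as estimated here.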

Compound 4, half-maximal inhibitory concentration: 6520 nM
The estimate for compound 4 lay 6.5-fold (0.81 log units) below the measured number; measured number outside the range, above it.
By their numbers in this assay, from the lowest: compound 3; then compounds 1, 2 and 4 (each within the scatter of the next).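

In this assay the second bromo, ortho to the hydroxy group, undid the advantage of 3-bromo-4-hydroxyphenyl (a 4.8-fold higher number from compound 3 to compound 4 (0.68 log units; beyond the scatter)). The 3,5-dibromo-4-hydroxyphenyl group kept no lead over the other aryl groups (a 1.3-fold higher number from compound 2 to compound 4 (0.10 log units; within the scatter); a 1.7-fold higher number from compound 1 to compound 4 (0.23 log units; within the scatter)), so this position tolerated the added bromo poorly here. Nothing available explains this rise. Left open is whether a smaller chloro or a methoxy at this position would keep the number of compound 3. Also open, on these data alone, is whether an amine in place of the hydroxy group would change the effect of the second bromo.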